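Solubility notes: biaryl amide series, pyrazole to pyridine

This account rests on a few compounds, and the source may have more. Where it says the series, first, only, none or still open, it means among the compounds named here.

Compound 1 `Cc1csc(-c2cc(NC(=O)c3ccc(OCc4ccccn4)cc3)c(C)cc2C)n1`: in a physicochemical assay for solubility, at pH 7.4 (a lower number here means a less soluble compound, a higher number a more soluble compound), compound 1 sits at a limit, < 1000 nM.
Compound 2 `Cc1cc(C)c(-c2c[nH]nc2C)cc1NC(=O)c1ccc(OCc2ccccn2)cc1`: in this assay compound 2 gives 33000 nM.

Among the compounds with values here, compound 2 holds the only number in this assay; the other value shown is a limit, (the limit of < 1000 nM in this assay, at which 1 of the 2 values shown sits). Within the data shown here, the one measured step at this position is an at least 33-fold higher number from compound 1 to compound 2 (1.51 log units; beyond the scatter), large and beyond the scatter, so the group on this aromatic carbon clearly matters for the read-out.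

Compound 3 `Cc1cc(C)c(-c2cccnc2)cc1NC(=O)c1ccc(OCc2ccccn2)cc1` carries the change (pyridin-3-yl in place of 3-methyl-1H-pyrazol-4-yl on an aromatic carbon). Among the measured compounds shown here, this replaces the only group that has reached a number, and no measured pair covers a pyridinyl here. Given that the thiazolyl analogue stayed at a limit while compound 2 rose, the expectation for compound 3 is a drop, estimated as a 4.1-fold lower number from compound 2 to compound 3 (0.62 log units; beyond the scatter), of a size between none and the measured step. Compound 3 is thus expected near 8000 nM, within 2000 nM to 30000 nM.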

Compound 3, solubility: 9000 nM
Compound 3: middle estimate off by 1.1-fold (0.05 log units), on the low side; the range from low to high includes it.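

In this assay, the change from 3-methyl-1H-pyrazol-4-yl to pyridin-3-yl gives a 3.7-fold lower number from compound 2 to compound 3 (0.56 log units; beyond the scatter), so a six-membered aromatic ring also reaches a number on this aromatic carbon, though not the highest one shown. Pyridin-3-yl, which carries 0 hydrogen-bond donors, still stands clear of the thiazolyl group, with an at least 9.0-fold higher number from compound 1 to compound 3 (0.95 log units; beyond the scatter); the pyrazolyl donor is therefore not needed to rise beyond the scatter from that group. Compound 1 remains a limit and not a number, so this last step gives only a bound: the limit of < 1000 nM in this assay, at which 1 of the 3 values shown sits.

The step from compound 2 swaps ring size, hetero atom count and donor count at once, and the values shown cannot separate these. From the compounds shown here alone, how pyridin-4-yl, a carboxylic acid or a morpholine would read on this aromatic carbon remains open.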